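Fluoro for Methoxy in a Small Antiproliferative Set

This account rests on a few compounds, and the source may have more. Where it says the series, first, only, none or still open, it means among the compounds named here.

Of the compounds shown here, three have been measured so far in a functional assay on HeLa cells (Homo sapiens) for antiproliferative activity, read by MTT assay; on this read-out higher numbers stand for weaker inhibition and lower numbers for stronger inhibition. Compound 1 (`COc1ccc(-c2ccnc(Nc3ccc([N+](=O)[O-])cc3)n2)cc1`) gives 980 nM. Compound 2 (`Clc1ccc(Nc2nccc(-c3ccc(Cl)cc3Cl)n2)c(Cl)c1`) gives 1560 nM, which lies within the usual scatter of the value for compound 1. Compound 3 (`COc1cccc(Nc2nccc(-c3ccc(F)cc3)n2)c1`) gives 145000 nM, so it inhibits far more weakly than compound 1, well beyond the scatter.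

Compound 4 (`O=[N+]([O-])c1ccc(Nc2nccc(-c3ccc(F)cc3)n2)cc1`) has not yet been measured. It differs from compound 1 by having fluoro in place of methoxy on an aromatic carbon, para to a large group (fluoro in place of methoxy on an aromatic carbon). For the measured compounds named here, no two measured compounds differ in only one place, so no measured step guides this change. Compound 3 also carries a 4-fluorophenyl and sits at 145000 nM, but it differs from compound 4 elsewhere too, so it supports only a cautious expectation of weaker inhibition. The expected change is modest: a 2.6-fold higher number from compound 1 to compound 4 (0.41 log units; beyond the scatter). For compound 4 the estimated value is 2500 nM, with an expected range of 500 nM to 20000 nM.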

Compound 4, half-maximal inhibitory concentration: 3510 nM
For compound 4 the middle estimate is 1.4-fold (0.15 log units) below the measured one, within the range that was stated.
By their numbers in this assay, from the lowest: compounds 1 and 2 (each within the scatter of the next); then compound 4; then compound 3.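

For the compounds shown here, this is the first pair in the set that differs in only one place, so it shows the effect of going from 4-methoxyphenyl to 4-fluorophenyl while the rest of the molecule stays the same. In this assay the swap gives a 3.6-fold higher number from compound 1 to compound 4 (0.55 log units; beyond the scatter) and so weakens inhibition: the group at this position does matter, although the loss is modest and the fluoro compound keeps measurable activity. Nothing available explains why the number rises.

On these data alone, it remains open how an amine, a hydroxyl or a longer chain such as ethoxy would behave at this position, and so whether the loss tracks the departure of methoxy or the arrival of fluoro. This single pair also cannot tell whether the same swap would give a similar step with a different group on the other side of the shared core.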